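The source may hold more compounds than are shown below. What is called first, only, known or untested is meant among the compounds shown, and "the series" means these compounds.

Measured so far:
compound 1 `CCNC1=NS(=O)(=O)c2cc(Cl)c(Cl)cc2N1`: 1000 nM
compound 2 `CCCNC1=NS(=O)(=O)c2cc(Cl)c(Cl)cc2N1`: 4700 nM
compound 3 `CCNC1=NS(=O)(=O)c2cc(OC)c(Cl)cc2N1`: 8100 nM

All numbers come from a functional assay (aorta) with Rattus norvegicus as the target, with a stated time of 90 min, at 37 degrees C; a lower number here means that less compound is needed, a higher number that more compound is needed for the effect. In this assay compound 1 gives 1000 nM. Lengthening the chain, (methyl in place of hydrogen on a saturated chain carbon, two bonds along the chain from an amine nitrogen), raises the number: a 4.7-fold higher number from compound 1 to compound 2 (0.67 log units; beyond the scatter). Changing the aromatic substituent raises it as well: an 8.1-fold higher number from compound 1 to compound 3 (0.91 log units; beyond the scatter). Compound 2 and compound 3 lie within the scatter of each other.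

Compound 4 `COc1cc2c(cc1Cl)NC(NC(C)C)=NS2(=O)=O` is not yet measured. It differs from compound 3 by methyl in place of hydrogen on a saturated chain carbon bound to an amine nitrogen and a saturated chain carbon. This is the same kind of change as that from compound 1 to compound 2, not the same: there the methyl entered on a saturated chain carbon two bonds along the chain from an amine nitrogen, here on a saturated chain carbon bound to an amine nitrogen and a saturated chain carbon. The cores of the two pairs differ by methoxy in place of chloro on an aromatic carbon.

A step of similar direction and size is expected, a 2.5-fold higher number from compound 3 to compound 4 (0.39 log units; beyond the scatter), because the related change gave a 4.7-fold higher number from compound 1 to compound 2 (0.67 log units; beyond the scatter). Compound 4 is therefore estimated at 20000 nM, with a range from 7000 nM to 60000 nM.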

Compound 4, half-maximal effective concentration: 37000 nM
Compound 4: the middle estimate sits 1.9-fold (0.27 log units) below what was measured; the measured number falls inside the stated range.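

In this assay, the methyl that turns ethylamino into isopropylamino gives a clear rise (a 4.6-fold higher number from compound 3 to compound 4 (0.66 log units; beyond the scatter)). Set beside the methyl step on the core of compound 1, the change carries over from the chloro core to the methoxy core with the same direction and size: the same change on two cores in this assay, a 4.7-fold higher number (0.67 log units; beyond the scatter) from compound 1 to compound 2 and a 4.6-fold higher number (0.66 log units; beyond the scatter) from compound 3 to compound 4, 1.0-fold (0.01 log units) apart, within the scatter of two such steps. This rests on a single pair on each core, and the methyl enters at a different chain carbon in each pair, so the agreement shows neither a general rule for this series nor how far the place of the methyl and the core act separately.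

Open, going by these compounds, is how isopropylamino behaves on the core of compound 1 and how propylamino behaves on the core of compound 3, the two pairings that would separate place from core. Also open, on these data alone, is whether the step persists with a longer chain such as butyl, or with another aromatic substituent such as fluoro.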